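The compounds below may be only part of what the source reports. "The series", "measured", "known", "first", "only" and "open" are said of these compounds alone.

Three compounds share the core of compound 1 `Cc1nc(S(C)(=O)=O)ccc1Oc1ncnc(OC2CCN(C(=O)O[C@@H](C)C(F)(F)F)CC2)c1F` and differ only in the group attached to an amine nitrogen in a ring. In a functional assay on isolated protein for inhibition of Glucose-dependent insulinotropic receptor (Rattus norvegicus), read by HTRF and cAMP accumulation (on this read-out lower numbers stand for an effect already at smaller amounts and higher numbers for an effect only at larger amounts of compound), compound 1 gives 109 nM, compound 2 `Cc1nc(S(C)(=O)=O)ccc1Oc1ncnc(OC2CCN(C(=O)SC(C)(C)C)CC2)c1F` gives 30.7 nM, and compound 3 `Cc1nc(S(C)(=O)=O)ccc1Oc1ncnc(OC2CCN(C(=S)OC(C)C)CC2)c1F` gives 1050 nM, the highest of the three numbers, beyond the scatter from both others. The change to compound 4 `Cc1nc(S(C)(=O)=O)ccc1Oc1ncnc(OC2CCN(C(=O)c3noc(C(C)(C)F)n3)CC2)c1F` is a group of 11 heavy atoms (6 carbon, 2 nitrogen, 2 oxygen, 1 fluorine; one five-membered aromatic ring with 3 hetero atoms) in place of a group of 6 heavy atoms (4 carbon, 1 oxygen, 1 sulfur; no ring), on an amine nitrogen in a ring. Going by the values given here, the steps that bear on it are a 9.6-fold higher number from compound 1 to compound 3 (0.98 log units; beyond the scatter) and a 34-fold higher number from compound 2 to compound 3 (1.53 log units; beyond the scatter): the group leaving compound 3 was the weakest of the three, and the entering group carries a carbonyl like the groups of compound 1 and compound 2. For compound 4 a return to lower numbers is therefore expected, an 18-fold lower number from compound 3 to compound 4 (1.24 log units; beyond the scatter). Compound 4 is estimated at 60 nM, within 15 nM to 300 nM.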

Compound 4, half-maximal effective concentration: 103 nM
The estimate for compound 4 lay 1.7-fold (0.23 log units) below the measured number; the measured number falls inside the stated range.
By their numbers in this assay, from the lowest: compound 2; then compounds 4 and 1 (each within the scatter of the next); then compound 3.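

In this assay, a carbonyl carrying a five-membered aromatic ring with 3 hetero atoms works on this ring nitrogen, giving a 10-fold lower number from compound 3 to compound 4 (1.01 log units; beyond the scatter). The ring group matches the 1-(trifluoromethyl)ethoxy group, with a 1.1-fold lower number from compound 1 to compound 4 (0.02 log units; within the scatter), yet it does not reach the (tert-butyl)sulfanyl group, with a 3.4-fold higher number from compound 2 to compound 4 (0.53 log units; beyond the scatter). Nothing available explains these steps. Still open, going by these compounds, is whether the aromatic ring itself matters, or whether a plain phenyl ring or a cyclohexyl ring on the carbonyl carbon would serve equally well. On these data alone, the part played by the fluorine on the ring's substituent is also open.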